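Thiazolyl for pyrazolyl on the six-membered core

The compounds below may be only part of what the source reports. "The series", "measured", "known", "first", "only" and "open" are said of these compounds alone.

Compound 3 `Cc1cc2c(cc1Cc1ccc(-n3cccn3)cc1)C(=O)N([C@H]1CCOC[C@@H]1O)CC2` gives 15 mL/min/kg in an ADME assay on microsomes from liver (Homo sapiens) for metabolic stability (a lower number here means slower removal, a higher number faster removal of the compound), the highest of the two numbers shown; the nearest is compound 1 `Cc1cc2c(cc1Cc1ccc(-c3cscn3)cc1)C(=O)N([C@H]1CCOC[C@@H]1O)C2` with 10 mL/min/kg, a gap within the scatter. Compound 2 `Cc1cc2c(cc1Cc1ccc(-n3ccnc3)cc1)C(=O)N([C@H]1CCOC[C@@H]1O)C2` reaches only a limit in this assay, < 8 mL/min/kg, which is the limit of < 8 mL/min/kg in this assay, at which 1 of the 3 values shown sits, and not a number. Compound 4 `Cc1cc2c(cc1Cc1ccc(-c3cscn3)cc1)C(=O)N([C@H]1CCOC[C@@H]1O)CC2` differs from compound 3 by 1,3-thiazol-4-yl in place of 1H-pyrazol-1-yl on an aromatic carbon. Going by the values given here, the one measured step that bears on this is an at least 1.2-fold lower number from compound 1 to compound 2 (0.09 log units; that floor lies within the scatter), where an azole attached through nitrogen replaced the same thiazolyl group on the shared core of compound 1 and compound 2 and the number did not move beyond the scatter. Compound 4 reverses that kind of change on the core of compound 3, so no step beyond the scatter is expected in this assay, with the small measured step leaning, if at all, toward a slightly higher number. Compound 4 is therefore expected to give 15 mL/min/kg in this assay, within 8 mL/min/kg to 28 mL/min/kg, an expected step of no change at the digits printed from compound 3 to compound 4 (within the scatter).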

Compound 4, clearance: 25 mL/min/kg
Compound 4: the middle estimate sits 1.7-fold (0.22 log units) below what was measured; the measured number falls inside the stated range.
By their numbers in this assay, from the lowest: compounds 1, 3 and 4 (each within the scatter of the next, the first and the last beyond it). At a limit, below all of these: compound 2.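

On the core of compound 3, 1,3-thiazol-4-yl in place of 1H-pyrazol-1-yl on an aromatic carbon, para to a large group, gives a 1.7-fold higher number from compound 3 to compound 4 (0.22 log units; within the scatter) in this assay. This pair gives a complete reading of an exchange of these azole groups at this position, and that reading stays within the scatter. With 1,3-thiazol-4-yl held constant, compound 1 gives 10 mL/min/kg and compound 4 gives 25 mL/min/kg, two values beyond the scatter of each other, so the shared thiazolyl group does not fix the number across the two cores.

From the compounds shown here alone, the full size of the change on the core of compound 1 stays open because compound 2 stands at a limit, not a number: the limit of < 8 mL/min/kg in this assay, at which 1 of the 4 values shown sits. Also open is how this position responds to a primary amine or a carboxylic acid in place of these five-membered aromatic rings.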